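Chloro-to-nitro swap in two lactone and lactam series

The source may hold more compounds than are shown below. What is called first, only, known or untested is meant among the compounds shown, and "the series" means these compounds.

Compound 1, `O=C1OC(c2ccc(Cl)cc2)=C/C1=C\c1ccccc1Cl`, gives 62.7% in a functional assay on the whole organism (strain Wistar) for inhibition, with Rattus norvegicus as the target, with stated times of 30 min and 2 h, at a dose of 20 mg/kg by the oral route; a lower number here means less inhibition, a higher number more inhibition at the dose given (going by the name of the read-out).
Compound 2, `O=C1OC(c2ccc(Cl)cc2)=C/C1=C\c1ccccc1[N+](=O)[O-]`, gives 4% in this assay.
Compound 3, `O=C1/C(=C/c2ccc(Cl)cc2)C=C(c2ccc(Cl)cc2)N1Cc1ccccc1`, gives 58.7% in this assay.

Compound 1 and compound 2 share a core and differ in one place: nitro in place of chloro on an aromatic carbon. This change produced a number 58.7 percentage points lower from compound 1 to compound 2 (beyond the scatter). Compound 3 carries a different core, and the difference between the two cores is not broken down here; what can be said is that the value of compound 3 sits close to that of compound 1 and far above that of compound 2.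

Compound 4, `O=C1/C(=C/c2ccc([N+](=O)[O-])cc2)C=C(c2ccc(Cl)cc2)N1Cc1ccccc1`, is not yet measured. It differs from compound 3 by nitro in place of chloro on an aromatic carbon. This is the same kind of change as from compound 1 to compound 2, but not the same: in compound 2 the nitro stands ortho to a large group, in compound 4 para to a large group. Given that the earlier step was a number 58.7 percentage points lower from compound 1 to compound 2 (beyond the scatter), a large fall is also expected here, a number 46.7 percentage points lower from compound 3 to compound 4 (beyond the scatter), though the different core and the different placement make the size uncertain. Compound 4 is thus estimated at 12%, between 0% and 38%.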

Compound 4, a percentage reported as inhibition, in the whole organism at one dose (the size of the read-out at that dose, not a potency): 12%
The estimate for compound 4 equals the measured number at the digits printed; measured number inside the range.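

Nitro in place of chloro on an aromatic carbon gave a number 46.7 percentage points lower from compound 3 to compound 4 (beyond the scatter) in this assay, a large fall on a second core to stand alongside the one on the core of compound 1. Set side by side, the two steps do not separate: the same change on two cores in this assay, a number 58.7 percentage points lower (beyond the scatter) from compound 1 to compound 2 and a number 46.7 percentage points lower (beyond the scatter) from compound 3 to compound 4, 12 percentage points apart, within the scatter of two such steps. For the compounds shown here, this shows the change carrying over between these two cores at this one dose, but it rests on only two pairs, which differ in the placement of the group as well as in the core (in compound 4 it stands para to a large group), so it shows neither that core and placement have no bearing nor why the number falls.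

The compounds shown carry only chloro or nitro at this place, so how an amine or a carboxylic acid on that aromatic carbon would compare stays open. Also open, going by these compounds, is whether the step would hold if the benzyl group of compound 3 gave way to a longer chain.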